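Hydroxy for Amino on the Uracil-Type Core of Compound 2

The source may report more compounds than this note shows. Statements on the series, on what has been measured and on what is new or still open speak of the compounds shown alone.

The study concerns small uracil-derived compounds tested in a functional assay on NCI-H460 cells (Homo sapiens) for inhibition, read by MTT assay, with a stated time of 72 h; a higher number here means a weaker inhibitor, a lower number a stronger inhibitor. Compound 1 `NCC(=O)Nc1c[nH]c(=O)[nH]c1=O` gives only a limit of the assay, > 100000 nM. Compound 3 `O=C(CCl)Nc1c[nH]c(=O)[nH]c1=O` gives 14000 nM. Going by the values given here, the one computed step among the measured compounds, an at least 7.1-fold lower number from compound 1 to compound 3 (0.85 log units; beyond the scatter), is a chloro in place of amino on a saturated chain carbon bound to a carbonyl carbon. Compound 2 `Nc1cn(COC(CO)CO)c(=O)[nH]c1=O` likewise gives only a limit, > 100000 nM. Two of the three values shown thus sit at the same point, (the limit of > 100000 nM in this assay, at which 2 of the 3 values shown sit), so compound 2 stands among the weakest measured, with no number of its own.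

The unmeasured compound 4 `O=c1[nH]c(=O)n(COC(CO)CO)cc1O` differs from compound 2 by hydroxy in place of amino on an aromatic carbon, a hydroxy in place of amino on an aromatic carbon. Among the compounds with values here, no measured step touches this ring position; the only measured step concerns a chain carbon, so it offers no direct guide. Compound 4 is therefore expected to give about 150000 nM, within 30000 nM to 1000000 nM. The expected step that the limit leaves unreadable from compound 2 to compound 4 is estimated to lie within the scatter, most likely again a limit.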

Compound 4, half-maximal inhibitory concentration: > 100000 nM
Compound 4: a limit, no number (the forecaster's own chance of this, stated with the estimate: 85%); the middle value is on the limit's open side.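

Compound 4 gives > 100000 nM, a limit of the assay and not a number. Compound 2 also gives only a limit, so no step can be read between compound 2 and compound 4: the limit of > 100000 nM in this assay, at which 3 of the 4 values shown sit.

The compounds shown leave open what hydroxy in place of amino on an aromatic carbon does to the number in this assay.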